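Ester chain branching and aortic inhibition

A few compounds are considered here, and "the series" means these few. Any claim that something is new, unique, unknown or untested is made for them only; others in the source may bear on it.

In a functional assay (aorta) with Oryctolagus cuniculus as the target (on this read-out higher numbers stand for weaker inhibition and lower numbers for stronger inhibition), compound 2 `CCO/C(O)=C1\C(C)=NC(C)=C(C(=O)OCCCN2C(=O)c3ccccc3S2(=O)=O)C1c1cccc([N+](=O)[O-])c1` gives 1.9 nM, and compound 1 `CO/C(O)=C1\C(C)=NC(C)=C(C(=O)OCCCN2C(=O)c3ccccc3S2(=O)=O)C1c1cccc([N+](=O)[O-])c1` gives 2.6 nM, the two numbers lying within the scatter of each other. Compound 3 `CC1=NC(C)=C(C(=O)OCCCN2C(=O)c3ccccc3S2(=O)=O)C(c2cccc([N+](=O)[O-])c2)/C1=C(\O)OC(C)C` differs from compound 2 by methyl in place of hydrogen on a saturated chain carbon bound to an oxygen on an unsaturated carbon and a saturated chain carbon. Among the compounds with values here, the only measured step that bears on this change, a 1.4-fold lower number from compound 1 to compound 2 (0.14 log units; within the scatter), was within the scatter. A further step of the same kind is therefore expected to stay within the scatter in this assay, so the step of a 1.1-fold lower number from compound 2 to compound 3 (0.05 log units; within the scatter) is the estimate. Compound 3 is estimated at 1.7 nM with a range from 0.7 nM to 4.5 nM.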

Compound 3, half-maximal inhibitory concentration: 1 nM
Beside the measured number, compound 3's estimate is 1.7-fold (0.23 log units) above it; low and high end bracket the measured number.
By their numbers in this assay, from the lowest: compounds 3, 2 and 1 (each within the scatter of the next, the first and the last beyond it).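

In this assay, within the data shown here, ethoxy to isopropoxy gives a 1.9-fold lower number from compound 2 to compound 3 (0.28 log units; within the scatter) and so shows no separable change by itself, but isopropyl in place of methyl on an oxygen on an unsaturated carbon gives a 2.6-fold lower number from compound 1 to compound 3 (0.41 log units; beyond the scatter) and is the first step at this position to clear the scatter, if only modestly. Two steps that each stay within the scatter thus add up to one that does not. Nothing available accounts for this result. As far as these compounds go, whether tert-butyl, cyclopentyl or a longer chain such as n-butyl on this oxygen would lower the number further or reverse the trend stays open.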